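Pyridinylcarbonyl in Place of Phenylsulfonyl on the Ring Nitrogen

This account rests on a few compounds, and the source may have more. Where it says the series, first, only, none or still open, it means among the compounds named here.

Compound 3 `Cc1ccc2[nH]c(C(=O)N[C@H]3CCN(S(=O)(=O)c4ccccc4)C[C@@H]3C(=O)NCCN(C)C)cc2c1` gives 16 uL/min in an ADME assay on cells (Hepatocyte, Rattus norvegicus) for metabolic stability (on this read-out higher numbers stand for fast clearance and lower numbers for slow clearance), the highest of the three numbers measured. Compound 1 `Cc1ccc2[nH]c(C(=O)N[C@H]3CN(S(=O)(=O)c4cnccn4)C[C@@H]3C(=O)NCCN(C)C)cc2c1` gives 12 uL/min, within the scatter of compound 3, whereas compound 2 `Cc1ccc2[nH]c(C(=O)N[C@H]3CN(S(=O)(=O)C4CCOCC4)C[C@@H]3C(=O)NCCN(C)C)cc2c1` gives 4 uL/min, a gap beyond the scatter. Among the measured compounds shown here, the only step measured between compounds differing in one place is a 3.0-fold lower number from compound 1 to compound 2 (0.48 log units; beyond the scatter). Compound 4 `Cc1ccc2[nH]c(C(=O)N[C@H]3CCN(C(=O)c4cccnc4)C[C@@H]3C(=O)NCCN(C)C)cc2c1` differs from compound 3 as follows: (pyridin-3-yl)carbonyl in place of phenylsulfonyl on an amine nitrogen in a ring. Here phenylsulfonyl leaves and (pyridin-3-yl)carbonyl enters on an amine nitrogen in a ring, a change of a different kind from the swap of oxan-4-yl for pyrazin-2-yl on a sulfonyl sulfur, so no measured step bears on it directly. Compound 4 is therefore expected to show no step beyond the scatter, a 1.3-fold lower number from compound 3 to compound 4 (0.12 log units; within the scatter). For compound 4 the estimate in this assay is 12 uL/min, with a range of 5 uL/min to 30 uL/min.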

Compound 4, intrinsic clearance in a liver preparation (reported as CLH), per the amount of preparation that the assay uses: 6 uL/min
Compound 4: the middle estimate sits 2.0-fold (0.30 log units) above what was measured; measured number inside the range.
By their numbers in this assay, from the lowest: compounds 2, 4, 1 and 3 (each within the scatter of the next, the first and the last beyond it).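

Replacing phenylsulfonyl with (pyridin-3-yl)carbonyl on the amine nitrogen in the ring gives a 2.7-fold lower number from compound 3 to compound 4 (0.43 log units; beyond the scatter) in this assay. This shows that the sulfonyl link itself can be exchanged on this nitrogen, whereas the earlier step changed only the group on the sulfonyl sulfur. The link and the aromatic ring change together here, so their shares in the step cannot be separated, and nothing available explains the step. On these data alone, a benzoyl group or a pyridin-3-ylsulfonyl group on the same nitrogen would separate the two, and that remains open.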